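Phenyl in place of benzyl: expectation for compound 4

This account rests on a few compounds, and the source may have more. Where it says the series, first, only, none or still open, it means among the compounds named here.

Among the measured compounds shown here, in a functional assay on SQ20B cells (Homo sapiens) for cytotoxicity, read by MTT assay, with a stated time of 72 h (a lower number here means a stronger inhibitor, a higher number a weaker inhibitor), compound 3 `Oc1ccc2oc(Cc3ccccc3)cc2c1CN1CCC(N2CCCCC2)CC1` gives 3000 nM, the lowest of the three numbers measured so far. Compound 1 `Oc1ccc2oc(Cc3ccccc3)cc2c1CN1CCC(O)CC1` gives 13000 nM and compound 2 `NC(=O)C1CCN(Cc2c(O)ccc3oc(Cc4ccccc4)cc23)CC1` gives 85000 nM. Every measured step changes the group on the saturated ring carbon: a 4.3-fold lower number from compound 1 to compound 3 (0.64 log units; beyond the scatter), a 28-fold lower number from compound 2 to compound 3 (1.45 log units; beyond the scatter) and a 6.5-fold higher number from compound 1 to compound 2 (0.82 log units; beyond the scatter). Compound 4 `Oc1ccc2oc(-c3ccccc3)cc2c1CN1CCC(N2CCCCC2)CC1` differs from compound 3 at another place: phenyl in place of benzyl on an aromatic carbon. For the measured compounds named here, no measured step touches this part of the shared core, so the series gives no direct guide to the size or direction of the change. For compound 4 the step of no change at the digits printed from compound 3 to compound 4 (within the scatter) is expected to stay within the scatter. Compound 4 is therefore estimated at 3000 nM, with a range from 1000 nM to 10000 nM.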

Compound 4, half-maximal inhibitory concentration: 2800 nM
Beside the measured number, compound 4's estimate is 1.1-fold (0.03 log units) above it, within the range that was stated.
By their numbers in this assay, from the lowest: compounds 4 and 3 (each within the scatter of the next); then compound 1; then compound 2.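

In this assay, phenyl in place of benzyl on the aromatic carbon next to the ring oxygen gives a 1.1-fold lower number from compound 3 to compound 4 (0.03 log units; within the scatter) and leaves compound 3 and compound 4 indistinguishable. Among the compounds shown here, this is the first step at this place, and here the benzyl group can give way to phenyl without a change beyond the scatter, while steps on the saturated ring carbon go beyond it. Nothing available explains this result. From the compounds shown here alone, whether a longer chain such as 2-phenylethyl, or a pyridinyl ring, would behave alike at this place remains open. Also open, going by these compounds, is whether the result holds with hydroxy or carbamoyl on the saturated ring carbon.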